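The source may report more compounds than this note shows. Statements on the series, on what has been measured and on what is new or still open speak of the compounds shown alone.

Measured values in an assay on membranes from brain for displacement of a labelled ligand from Sigma non-opioid intracellular receptor 1 (Cavia porcellus), read by scintillation counting, with a stated time of 120 min; a higher number here means a weaker inhibitor, a lower number a stronger inhibitor:

Compound 1 `COc1cc2c(c(OC)c1OC)CCN(CCCC(=O)c1c(C)c(OC)c(OC)c(OC)c1OC)C2` gives > 1000 nM, which is a limit of this assay and not a number.
Compound 2 `COc1cc2c(cc1OC)CN(CCCCCC(=O)c1c(C)c(OC)c(OC)c(OC)c1OC)CC2` gives > 1000 nM, again a limit rather than a number.
Compound 3 `COc1cc2c(c(OC)c1OC)CCN(CCCCCC(=O)c1c(C)c(OC)c(OC)c(OC)c1OC)C2` gives > 1000 nM, also a limit and not a number.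

Compound 2 therefore stands at a limit only; the two further values shown are limits as well, so no order among the three can be read from this assay. Among the measured compounds shown here, the single measured step in one place, from compound 2 to compound 3, is a step that the two limits leave unreadable from compound 2 to compound 3. All three values sit at the same point, (the limit of > 1000 nM in this assay, at which 3 of the 3 values shown sit), and no step beyond the scatter is visible anywhere in the series.

Compound 4 `COc1cc2c(c(OC)c1OC)CN(CCCCCC(=O)c1c(C)c(OC)c(OC)c(OC)c1OC)CC2` is not yet measured. Relative to compound 2 the change is methoxy in place of hydrogen on an aromatic carbon. The measured step from compound 2 to compound 3 is the one that bears on this change, but its size is not readable, so it gives no direction and no size for the expected step, only that nothing beyond the scatter has been seen.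

For compound 4 the estimate in this assay is 3000 nM, with a range from 1000 nM to 15000 nM, most likely reported again as a limit. The expected step is a step that the limit leaves unreadable from compound 2 to compound 4, none beyond the scatter.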

Compound 4, inhibition constant: > 1000 nM
Compound 4 gave a limit, no number; the forecaster's own chance of this, stated with the estimate: 85%; the middle value is on the limit's open side.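

No new step can be read in this assay from compound 2 to compound 4, since both compounds give only a limit and the methoxy in place of hydrogen has no readable size. All values coincide: the limit of > 1000 nM in this assay, at which 4 of the 4 values shown sit.

The compounds shown leave open whether any member of this series gives a number in this assay, and so which change would shift it.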